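This account rests on a few compounds, and the source may have more. Where it says the series, first, only, none or still open, it means among the compounds named here.

Three compounds have so far been measured in an assay on isolated protein for inhibition of serine/threonine-protein kinase 10 (Homo sapiens), read by thermal shift assay, tested at 10 uM; a higher number here means that the compound stabilises the target more against heat, a lower number that the compound stabilises the target less:

Compound 1, `CCOc1ccc(NC(=O)Nc2cc(C(C)(C)C)nn2-c2ccccc2)cc1`, gives 0.8 degrees C.
Compound 2, `CC(C)(C)c1cc(NC(=O)Nc2ccc(F)cc2)n(-c2ccccc2)n1`, gives 6.5 degrees C.
Compound 3, `CC(C)(C)c1cc(NC(=O)Nc2ccccc2)n(-c2ccccc2)n1`, gives 7.2 degrees C.

Compound 2 stands second highest of the three. Its nearest neighbour is compound 3, and the step of a number 0.70 degrees C higher from compound 2 to compound 3 (within the scatter) lies within the scatter, so the two cannot be told apart. The step of a number 5.7 degrees C higher from compound 1 to compound 2 (beyond the scatter), by contrast, is far beyond the scatter.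

Compound 4, `Cc1ccc(NC(=O)Nc2cc(C(C)(C)C)nn2-c2ccccc2)cc1`, has not yet been measured. It differs from compound 2 in one place: methyl in place of fluoro on an aromatic carbon. The measured steps that bear on this position are a number 5.7 degrees C higher from compound 1 to compound 2 (beyond the scatter) and a number 6.4 degrees C higher from compound 1 to compound 3 (beyond the scatter), both large and both in the same direction, and a number 0.70 degrees C higher from compound 2 to compound 3 (within the scatter), which is within the scatter. Together they show that the ethoxy compound sits far below the fluoro and unsubstituted compounds at this position, while fluoro and hydrogen are not distinguished. Methyl itself has not been tried, so the outcome for compound 4 is uncertain. Compound 4 is expected to lie between compound 1 and compound 2, with an estimated step of a number 1.5 degrees C lower from compound 2 to compound 4 (beyond the scatter). The estimate for compound 4 is 5 degrees C, with a range from 2.5 degrees C to 7.5 degrees C.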

Compound 4, shift of the target's melting temperature: 4.7 degrees C
The estimate for compound 4 lay 0.30 degrees C above the measured number; low and high end bracket the measured number.
By their numbers in this assay, from the lowest: compound 1; then compound 4; then compounds 2 and 3 (each within the scatter of the next).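

In this assay the methyl compound joins neither side of the earlier divide at this position: a number 1.8 degrees C lower from compound 2 to compound 4 (beyond the scatter) and a number 2.5 degrees C lower from compound 3 to compound 4 (beyond the scatter) stand alongside a number 3.9 degrees C higher from compound 1 to compound 4 (beyond the scatter) and so give methyl a place of its own, clear of the fluoro and hydrogen compounds and clear of the ethoxy compound. The change from fluoro to methyl keeps the count of one heavy atom and adds no hydrogen-bond donor or acceptor, yet the two compounds still differ beyond the scatter, so these counts alone do not set the number on this aromatic carbon. No measurement among the data bears on why these steps arise.

The compounds shown leave open whether chlorine, a hydroxyl group or an amine on this carbon would stay level with the fluoro and hydrogen compounds or fall towards the methyl compound. They also leave open where methoxy or a longer chain such as propyl would fall relative to the methyl and ethoxy compounds, and whether the same order would hold at another carbon of this ring.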